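The compounds below may be only part of what the source reports. "The series", "measured", "known", "first", "only" and "open" are said of these compounds alone.

Two compounds share one core and differ only in the group carried on a saturated chain carbon bound to an aromatic carbon. Compound 1 `NS(=O)(=O)c1cc(-c2nnc(CN3CCN(Cc4ccccc4)CC3)o2)c(Cl)cc1SCc1ccccc1` is one of them, compound 2 `CCOC(=O)c1cn(Cc2nnc(-c3cc(S(N)(=O)=O)c(SCc4ccccc4)cc3Cl)o2)nn1` the other. In a functional assay on HeLa cells (Homo sapiens) for cytotoxicity, read by MTT assay, with a stated time of 72 h (a higher number here means a weaker inhibitor, a lower number a stronger inhibitor), compound 1 gives 17000 nM. In this assay compound 2 gives 122000 nM, the higher of the two numbers, and its gap to compound 1 lies beyond the usual scatter of repeated measurements, so compound 2 is the weaker inhibitor of the pair.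

Compound 3 `NS(=O)(=O)c1cc(-c2nnc(CNS(=O)(=O)c3ccc(Cl)cc3)o2)c(Cl)cc1SCc1ccccc1` has not yet been measured. It keeps the core of compound 2 and changes one group: ((4-chlorophenyl)sulfonyl)amino in place of 4-(ethoxycarbonyl)-1H-1,2,3-triazol-1-yl on a saturated chain carbon bound to an aromatic carbon. Going by the values given here, no measured pair shows this particular change, so its effect can only be judged from the two numbers already in hand.

Compound 3 is expected to give about 50000 nM in this assay, with a range from 12000 nM to 200000 nM. This estimate means a step of a 2.4-fold lower number from compound 2 to compound 3 (0.39 log units; beyond the scatter) that is expected to lower the number beyond the scatter, while still staying above the value compound 1 gives, 17000 nM.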

Compound 3, half-maximal inhibitory concentration: 24000 nM
The estimate for compound 3 lay 2.1-fold (0.32 log units) above the measured number, within the range that was stated.
By their numbers in this assay, from the lowest: compounds 1 and 3 (each within the scatter of the next); then compound 2.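

In this assay, the change to ((4-chlorophenyl)sulfonyl)amino on a saturated chain carbon bound to an aromatic carbon gives a 5.1-fold lower number from compound 2 to compound 3 (0.71 log units; beyond the scatter), a modest step but one that shows this position can alter the cytotoxic reading. With compound 3 at 24000 nM and compound 1 at 17000 nM, two quite different groups give values within the scatter of each other, so compound 2, the one carrying 4-(ethoxycarbonyl)-1H-1,2,3-triazol-1-yl, is the one that stands apart as the weakest of the three. The swap replaces a five-membered aromatic ring with a six-membered one and also adds a hydrogen-bond donor and a chlorine, all at once, so no single feature can be credited with the step, and nothing measured here explains it.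

The compounds shown leave open whether the triazole itself or its ethyl ester goes with the weaker number, which a carboxylic acid or a simple methyl group in place of the ethoxycarbonyl group would help to separate. They also leave open what the chlorine of the entering group contributes, a question that a plain phenylsulfonylamino group or a 4-methoxyphenyl version could address.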